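This account rests on a few compounds, and the source may have more. Where it says the series, first, only, none or still open, it means among the compounds named here.

Of the compounds shown here, two have numbers so far in an ADME assay (liver) for metabolic stability, with Liver microsome (Homo sapiens) as the target, read by LC-MS, using microsomes, with a stated time of 1 h, tested at 5 uM; a lower number here means that less of the compound is left, a higher number that more of the compound is left. Compound 1 `Cc1nc(-c2ccccc2)c(C(=O)N2CCN(c3cccc(C)c3C)CC2)o1` gives 29.8%, and compound 2 `COc1cc(OC)cc(N2CCN(C(=O)c3oc(C)nc3-c3ccc(F)cc3)CC2)c1` gives 12.9%. Compound 2 therefore stands lower of the two, and the gap to compound 1 lies beyond the scatter of repeated measurements. These two compounds differ in more than one place, so they do not show what a single change does. Compound 3 `COc1cc(OC)cc(N2CCN(C(=O)c3oc(C)nc3-c3ccccc3)CC2)c1` has not been measured yet. It differs from compound 2 by one swap, hydrogen in place of fluoro on an aromatic carbon, or 4-fluorophenyl to phenyl. Among the measured compounds shown here, no measured step shows the effect of this swap, so the expectation in this assay is no step beyond the scatter. The estimated change is a number 1.9 percentage points lower from compound 2 to compound 3 (within the scatter). For compound 3 the expected value is 11%, with a range of 4% to 24%.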

Compound 3, percent of the compound remaining: 15.8%
For compound 3 the middle estimate is 4.8 percentage points below the measured one; low and high end bracket the measured number.
By their numbers in this assay, from the lowest: compounds 2 and 3 (each within the scatter of the next); then compound 1.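

In this assay, hydrogen in place of fluoro on the aromatic ring gives a clean single-place comparison that the first two compounds could not offer: the change is a number 2.9 percentage points higher from compound 2 to compound 3 (within the scatter) and so does not separate 4-fluorophenyl from phenyl. The group on the amine nitrogen in a ring can now also be read alone, and 3,5-dimethoxyphenyl in place of 2,3-dimethylphenyl gives a number 14 percentage points lower from compound 1 to compound 3 (beyond the scatter) in this comparison. No measurement at hand explains the size of either step.

Going by these compounds, it remains open whether a chloro group or a nitrile at that same place on the phenyl ring would shift the percentage remaining. On these data alone, it is also open whether fluoro and hydrogen would still match with 2,3-dimethylphenyl on the amine nitrogen.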